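This account rests on a few compounds, and the source may have more. Where it says the series, first, only, none or still open, it means among the compounds named here.

The measured compounds and their values:

Compound 1 `Cc1cccc(N2CCC(C(=O)Nc3ccc4c(c3)NC(=O)CO4)CC2)c1` gives 490 nM in a functional assay for antagonist activity at transient receptor potential cation channel subfamily V member 1 (Homo sapiens), read by FLIPR and calcium flux; a lower number here means a stronger inhibitor, a higher number a weaker inhibitor.
Compound 2 `O=C(Nc1ccc2c(c1)NC(=O)C(CCO)O2)C1CCN(c2cc(F)c(F)c(F)c2)CC1` gives 5 nM in this assay.
Compound 3 `COC(=O)CC1Oc2ccc(NC(=O)C3CCN(c4cc(F)cc(F)c4)CC3)cc2NC1=O` gives 890 nM in this assay.

Among these three numbers, compound 1 stands second highest. Its nearest neighbour is compound 3, whose number is somewhat higher, but the two lie within the usual scatter of repeated measurements, so nothing separates them in this assay. Compound 2, by contrast, sits far below both, with a gap that goes well beyond the scatter; compound 2 differs from compound 1 in several places at once, so that gap cannot be pinned on any single change.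

The step under consideration leads from compound 1 to compound 4 `COc1cccc(N2CCC(C(=O)Nc3ccc4c(c3)NC(=O)CO4)CC2)c1`, which has not yet been measured in this assay. The change is confined to one position: methoxy in place of methyl on an aromatic carbon. Within the data shown here, no measured pair in this set shows the same exchange in isolation, so there is no direct precedent here for its effect.

Since methoxy enters where methyl leaves and everything else in the molecule stays the same, the expected step of a 1.2-fold lower number from compound 1 to compound 4 (0.07 log units; within the scatter) is small and most likely within the scatter, with no clear direction. Compound 4 is therefore estimated at 420 nM, with a range from 150 nM to 1300 nM.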

Compound 4, half-maximal inhibitory concentration: 1420 nM
Compound 4: the middle estimate sits 3.4-fold (0.53 log units) below what was measured, outside the stated range (above it).
By their numbers in this assay, from the lowest: compound 2; then compounds 1, 3 and 4 (each within the scatter of the next, the first and the last beyond it).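

The exchange of methyl for methoxy on this aromatic carbon, meta to a large group, amounts to a 2.9-fold higher number from compound 1 to compound 4 (0.46 log units; beyond the scatter) in this assay and so lies beyond the scatter. Among these compounds, this is the first pair in the set that differs in one place only, which makes it the first reading of a single change: the earlier compounds could not separate the contribution of this position from their other differences. Here the position does respond, since 3-methoxyphenyl gives a modestly weaker inhibitor than 3-methylphenyl, even though the entering group adds only one carbon-free heavy atom and one hydrogen-bond acceptor to the count. Nothing available explains why the step runs in this direction.

Going by these compounds, whether the same loss would follow from other groups on that carbon stays open, as a single pair cannot say how a hydroxyl, a chlorine or an ethyl group would compare with methyl and methoxy. On these data alone, it also stays open whether methoxy in place of methyl would have the same effect with a different substitution on the ring or a different side chain on the shared core.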